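Removing the heptyl chain from compound 3

A few compounds are considered here, and "the series" means these few. Any claim that something is new, unique, unknown or untested is made for them only; others in the source may bear on it.

Compound 1 `CCCCc1ccc(NS(=O)(=O)c2ccc(N3CCNC3=O)cc2)cc1`: 610 nM
Compound 2 `Cc1ccc(NS(=O)(=O)c2ccc(N3CCNC3=O)cc2)cc1C`: 230 nM
Compound 3 `CCCCCCCc1ccc(NS(=O)(=O)c2ccc(N3CCNC3=O)cc2)cc1`: > 1000 nM (a limit)

In a functional assay on HT-29 cells (Homo sapiens) for antiproliferative activity, read by sulforhodamine B assay, with a stated time of 48 h (a lower number here means a stronger inhibitor, a higher number a weaker inhibitor), compound 3 has no exact number and stands at the limit of > 1000 nM in this assay, at which 1 of the 3 values shown sits. Compound 4 `O=C1NCCN1c1ccc(S(=O)(=O)Nc2ccccc2)cc1` carries hydrogen in place of heptyl on an aromatic carbon. Within the data shown here, the only measured step bearing on this chain is an at least 1.6-fold higher number from compound 1 to compound 3 (0.21 log units; that floor lies within the scatter). Among the measured compounds shown here, that step gives a floor and no exact size, and no measured step removes the chain entirely. Compound 1 gives 610 nM, and compound 2 gives 230 nM, so a number not far from these remains plausible. An expected step of an at least 1.1-fold lower number from compound 3 to compound 4 (0.04 log units; that floor lies within the scatter) is estimated, with no clear change beyond the scatter. Compound 4 is expected at 900 nM, within an estimated range from 300 nM to 3000 nM.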

Compound 4, half-maximal inhibitory concentration: 280 nM
The estimate for compound 4 lay 3.2-fold (0.51 log units) above the measured number; the whole stated range lies above it.
By their numbers in this assay, from the lowest: compounds 2 and 4 (each within the scatter of the next); then compound 1. At a limit, above all of these: compound 3.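

Measured in this assay hydrogen on this aromatic carbon does better than either chain, with a 2.2-fold lower number from compound 1 to compound 4 (0.34 log units; beyond the scatter) and an at least 3.5-fold lower number from compound 3 to compound 4 (0.55 log units; beyond the scatter) as the two steps, so no chain is needed here for activity. Compound 3 has only a limit, which makes its step a floor: the limit of > 1000 nM in this assay, at which 1 of the 4 values shown sits. The step of a 1.2-fold higher number from compound 2 to compound 4 (0.09 log units; within the scatter) leaves phenyl and 3,4-dimethylphenyl on the sulfonamide nitrogen not told apart. As far as these compounds go, how an amine or a carboxylic acid on this aromatic carbon would compare stays open, as does the effect of a chain shorter than butyl, such as ethyl.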